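Cyclohexyl for cyclopentyl on compound 3

A few compounds are considered here, and "the series" means these few. Any claim that something is new, unique, unknown or untested is made for them only; others in the source may bear on it.

In a functional assay on M21 cells (Homo sapiens) for inhibition, read by sulforhodamine B assay, with a stated time of 48 h (a lower number here means a stronger inhibitor of growth, a higher number a weaker inhibitor of growth), compound 1 `c1ccc(-c2ccc(NC3=NCCO3)cc2)cc1` gives 8800 nM and compound 2 `c1cc(OC2CCCC2)ccc1NC1=NCCO1` gives 21100 nM, while compound 3 `c1cc(NC2=NCCO2)cc(OC2CCCC2)c1` gives 76900 nM as the highest of the three numbers, with its gaps to both others beyond the scatter.

Compound 4 `c1cc(NC2=NCCO2)cc(OC2CCCCC2)c1` carries cyclohexyl in place of cyclopentyl on an oxygen on an aromatic ring, a change counted as cyclohexyl in place of cyclopentyl on an oxygen on an aromatic ring and not yet tested.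

Within the data shown here, no measured pair covers this swap. The closest is a 2.4-fold higher number from compound 1 to compound 2 (0.38 log units; beyond the scatter) in the series, and that step concerns cyclopentyloxy in place of phenyl on an aromatic carbon, so it is only a loose guide to size. In this assay a step no larger than that one is expected, with a slight lean towards a lower number and no firm direction from the data. The expected change is a 1.3-fold lower number from compound 3 to compound 4 (0.11 log units; within the scatter) by this estimate, which stays within the scatter. Compound 4 is estimated at 60000 nM with an expected range from 25000 nM to 130000 nM in this series.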

Compound 4, concentration for 50% growth inhibition: 12000 nM
For compound 4 the middle estimate is 5.0-fold (0.70 log units) above the measured one, outside the stated range (below it).
By their numbers in this assay, from the lowest: compounds 1, 4 and 2 (each within the scatter of the next, the first and the last beyond it); then compound 3.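

Among these compounds, until now the only step concerned cyclopentyloxy in place of phenyl on an aromatic carbon, which left the group on the oxygen untested. In this assay, a 6.4-fold lower number from compound 3 to compound 4 (0.81 log units; beyond the scatter) shows that this place responds to the ring alone: cyclohexyl in place of cyclopentyl is a purely carbon ring for a purely carbon ring, with no hydrogen-bond donors or acceptors and no net charge on either side, yet the step lies beyond the scatter. Nothing measured on these compounds accounts for the size or direction of this step.

One step cannot show whether the trend continues to cycloheptyl or breaks with an open chain such as n-hexyl or a ring carrying an amine such as piperidin-4-yl. Going by these compounds, whether cyclohexyl in place of cyclopentyl on compound 2 would give a step of similar size also remains open.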